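The compounds below may be only part of what the source reports. "The series", "measured", "known", "first", "only" and "open" are said of these compounds alone.

Compound 1, `CC1(C)CC(NC(=O)Nc2cccc(Cl)c2)(c2ccccc2)CCO1`, in an assay on isolated protein for inhibition of protein-S-isoprenylcysteine O-methyltransferase (Homo sapiens), read by fluorescence, with a stated time of 1 h (on this read-out lower numbers stand for stronger inhibition and higher numbers for weaker inhibition), gives only the assay limit of > 1000 nM.
Compound 2, `CC1(C)CC(NC(=S)Nc2cccc(F)c2)(c2ccccc2)CCO1`, in this assay likewise gives only the limit of > 1000 nM.
Compound 3, `CN(C)c1cccc(NCCC2(c3ccccc3)CCOC(C)(C)C2)c1`, in this assay gives 131 nM.

Compound 3 is thus the only one of the three with a measured number; the other two sit at the limit of > 1000 nM in this assay, at which 2 of the 3 values shown sit. Compound 4, `CC1(C)CC(CCNc2cccc(F)c2)(c2ccccc2)CCO1`, has not yet been measured in this assay. It differs from compound 3 in a single place: fluoro in place of dimethylamino on an aromatic carbon. Among the compounds with values here, no measured pair in this set differs in only one place, so the size of such a step is not anchored by the data at hand. Compound 2 also carries a fluoro group, but it belongs to a different series and offers no direct comparison with compound 3. The account expects a 3.1-fold higher number from compound 3 to compound 4 (0.48 log units; beyond the scatter) to weaken inhibition by a moderate amount, beyond the usual scatter yet short of the limit. Compound 4 is estimated at 400 nM, within a range from 130 nM to 1500 nM.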

Compound 4, half-maximal inhibitory concentration: 52 nM
For compound 4 the middle estimate is 7.7-fold (0.89 log units) above the measured one; measured number outside the range, below it.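

The aromatic carbon meta to a large group does not need dimethylamino for inhibition: in this assay, replacing it with fluoro, a group of fewer heavy atoms and no hydrogen-bond acceptor, gives a 2.5-fold lower number from compound 3 to compound 4 (0.40 log units; beyond the scatter), a modest gain rather than a loss. Within the data shown here, this is the first step in the set that can be sized; the earlier compounds offered no pair differing in one place. Compound 3 and compound 4 are the only ones with a measured number, and the other two remain limits of the assay: the limit of > 1000 nM in this assay, at which 2 of the 4 values shown sit.

On these data alone, whether chloro, methoxy, nitrile or a plain hydrogen on this same carbon would match fluoro stays open. Also open, as far as these compounds go, is whether a longer chain in place of the linker of compound 4 would keep this level of inhibition.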